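Trimming propargylsulfanyl to methylsulfanyl on the shared core

The source may report more compounds than this note shows. Statements on the series, on what has been measured and on what is new or still open speak of the compounds shown alone.

compound 1 `OCC#CCSc1cnc2ccccc2c1SCC#CCCl` — 3.3 ug/mL
compound 2 `CSc1cnc2ccccc2c1[Se]CC#CCCl` — 1.7 ug/mL
compound 3 `C#CCSc1cnc2ccccc2c1SCC#CCCl` — 2.9 ug/mL

In a functional assay on CCRF-CEM cells (Homo sapiens) for antiproliferative activity, with a stated time of 72 h (on this read-out lower numbers stand for stronger inhibition and higher numbers for weaker inhibition), compound 3 stands second highest of the three numbers, within the scatter of compound 1 and of compound 2. Compound 4 `CSc1cnc2ccccc2c1SCC#CCCl` carries, relative to compound 3, (hydrogen in place of ethynyl on a saturated chain carbon bound to a sulfur); read one bond further out, this is propargylsulfanyl to methylsulfanyl. For the measured compounds named here, the only measured step touching that chain is a 1.1-fold lower number from compound 1 to compound 3 (0.06 log units; within the scatter), which stayed within the scatter, so altering this chain has so far left the number essentially unchanged. Going by the values given here, compound 2, which also bears a methylsulfanyl group but has selenium in the other position, gives 1.7 ug/mL, offering no direct step. Compound 4 is therefore expected to give about 2.5 ug/mL, between 1.2 ug/mL and 5 ug/mL. The expected step of a 1.2-fold lower number from compound 3 to compound 4 (0.06 log units; within the scatter) is estimated to lie within the scatter.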

Compound 4, concentration for 50% inhibition: 2.5 ug/mL
Compound 4: middle estimate and measured number agree at the digits printed; low and high end bracket the measured number.
By their numbers in this assay, from the lowest: compounds 2, 4, 3 and 1 (each within the scatter of the next).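

Replacing ethynyl with hydrogen on the saturated chain carbon bound to a sulfur (a 1.2-fold lower number from compound 3 to compound 4 (0.06 log units; within the scatter)) and replacing 3-hydroxyprop-1-yn-1-yl with hydrogen there (a 1.3-fold lower number from compound 1 to compound 4 (0.12 log units; within the scatter)) both stay within the scatter, so this chain can be cut back to methylsulfanyl with no readable change in the number. Sulfur in place of selenium, read directly for the first time (a 1.5-fold higher number from compound 2 to compound 4 (0.17 log units; within the scatter)), also stays within the scatter. No measurement is available here to explain these results. From the compounds shown here alone, whether an amine or a carboxylic acid at this chain carbon would shift the number remains open.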